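The compounds below may be only part of what the source reports. "The series", "measured", "known", "first", "only" and "open" are said of these compounds alone.

Measured in a functional assay on A375P cells (Homo sapiens) for antiproliferative activity, read by MTT assay, with a stated time of 24 h; on this read-out lower numbers stand for stronger inhibition and higher numbers for weaker inhibition:

Compound 1, `O=C(Nc1ccc(-n2ccc3c(NC(=O)c4ccccc4)ncnc32)cc1)c1ccc(Cl)c(Cl)c1`, gives 2000 nM.
Compound 2, `O=C(Nc1ccc(-n2ccc3c(NC(=O)c4ccccc4)ncnc32)cc1)c1ccc(Cl)c(C(F)(F)F)c1`, gives 2300 nM.
Compound 3, `Nc1ncnc2c1ccn2-c1ccc(NC(=O)Nc2ccc(Cl)c(C(F)(F)F)c2)cc1`, gives 8100 nM.

Compound 1 and compound 2 share one core; compound 3 carries another, and the difference between the two cores is not broken down here. Compound 3 stands highest of the three numbers, beyond the scatter against both compound 2 and compound 1. Between compound 1 and compound 2 the change is chloro in place of trifluoromethyl on an aromatic carbon, and the step of a 1.2-fold lower number from compound 2 to compound 1 (0.06 log units; within the scatter) lies within the scatter, so those two numbers cannot be put in order.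

Compound 4, `Nc1ncnc2c1ccn2-c1ccc(NC(=O)Nc2ccc(Cl)c(Cl)c2)cc1`, is not yet measured. It differs from compound 3 by chloro in place of trifluoromethyl on an aromatic carbon, the same change as from compound 2 to compound 1, at a place described in the same words. For the measured compounds named here, only one measured instance of this change exists, and it sits on a different core, so the expectation rests on that single step and nothing more. For compound 4 the step in this assay is expected to be a 1.2-fold lower number from compound 3 to compound 4 (0.06 log units; within the scatter), because the matching step a 1.2-fold lower number from compound 2 to compound 1 (0.06 log units; within the scatter) stayed within the scatter. Compound 4 is therefore expected to sit close to compound 3 rather than to move clearly in either direction. The estimate for compound 4 is 7000 nM, with a range from 3500 nM to 14000 nM expected to cover most repeats.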

Compound 4, half-maximal inhibitory concentration: 5400 nM
Compound 4: middle estimate off by 1.3-fold (0.11 log units), on the high side; measured number inside the range.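

In this assay, chloro in place of trifluoromethyl on an aromatic carbon, ortho to a chloro group, gives a 1.5-fold lower number from compound 3 to compound 4 (0.18 log units; within the scatter) and so stays within the scatter, which leaves compound 3 and compound 4 without an order. Across the two matched pairs the change therefore carries over from one core to the other without a step beyond the scatter, but this rests on only two pairs, at one place and in one cell assay, and it shows neither that the two groups are interchangeable elsewhere in the series nor why the numbers hold. The two steps themselves do not differ in any readable way: the same change on two cores in this assay, a 1.2-fold lower number (0.06 log units; within the scatter) from compound 2 to compound 1 and a 1.5-fold lower number (0.18 log units; within the scatter) from compound 3 to compound 4, 1.3-fold (0.12 log units) apart, within the scatter of two such steps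

Still open, as far as these compounds go, is whether a different group at this same place, such as a nitrile, a methoxy group, an amine or a bare hydrogen, would move the number beyond the scatter on either core. Also open, from the compounds shown here alone, is whether the parity of chloro and trifluoromethyl would hold in another cell line or with a longer exposure, and whether it would survive replacement of the chloro group that stays in place in all four compounds, for instance by fluoro or methyl.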